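Amide side chain: from compound 3 to compound 4

This account rests on a few compounds, and the source may have more. Where it says the series, first, only, none or still open, it means among the compounds named here.

In an ADME assay on the whole organism (plasma, strain CD1) for pharmacokinetics, with Mus musculus as the target, read by LC-MS, at a dose of 5 mg/kg by the oral route (a higher number here means more compound in the circulation at the dose given, a lower number less compound in the circulation), compound 1 `Cc1c(Oc2cnc(C(=O)NCCO)cn2)ccc2c1B(O)OC2` gives 13100 nM while compound 2 `Cc1c(Oc2cnc(C(=O)NC(C)CO)cn2)ccc2c1B(O)OC2` gives 11100 nM and compound 3 `CCC[C@H](CO)NC(=O)c1cnc(Oc2ccc3c(c2C)B(O)OC3)cn1` gives 10800 nM with the same shared core. Compound 3 therefore stands within the scatter of both other compounds, and the three numbers carry no order.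

Compound 4 `Cc1c(Oc2cnc(C(=O)N[C@@H](CO)CC(F)(F)F)cn2)ccc2c1B(O)OC2` is not yet measured. Its difference from compound 3 is trifluoromethyl in place of ethyl on a saturated chain carbon, two bonds along the chain from an amide-type nitrogen and amounts to trifluoromethyl in place of ethyl on a saturated chain carbon, two bonds along the chain from an amide-type nitrogen.

Among the measured compounds shown here, three measured steps bear on this change. Adding methyl gives a 1.2-fold lower number from compound 1 to compound 2 (0.07 log units; within the scatter) and adding propyl gives a 1.2-fold lower number from compound 1 to compound 3 (0.08 log units; within the scatter) on the chain carbon bound to the amide-type nitrogen. The closest comparison is a 1.0-fold lower number from compound 2 to compound 3 (0.01 log units; within the scatter) and it changes the chain in the same region. All three lie within the scatter, but none of them introduces trifluoromethyl, so the data do not test that group directly.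

On this evidence, no step beyond the scatter is expected. The estimated move in this assay is a 1.1-fold lower number from compound 3 to compound 4 (0.03 log units; within the scatter) and it remains an expectation until measured. For compound 4 the estimate is 10000 nM with an expected range from 5000 nM to 20000 nM at the same dose.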

Compound 4, maximal plasma concentration: 5110 nM
Beside the measured number, compound 4's estimate is 2.0-fold (0.29 log units) above it, within the range that was stated.
By their numbers in this assay, from the lowest: compound 4; then compounds 3, 2 and 1 (each within the scatter of the next).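

In this assay, among the compounds shown here, trifluoromethyl in place of ethyl gives the first step in this amide side chain that lies beyond the scatter: a 2.1-fold lower number from compound 3 to compound 4 (0.33 log units; beyond the scatter). Compound 4 also stands apart from the two shorter-chain compounds, with a 2.2-fold lower number from compound 2 to compound 4 (0.34 log units; beyond the scatter) and a 2.6-fold lower number from compound 1 to compound 4 (0.41 log units; beyond the scatter), although the methyl and propyl changes among compound 1, compound 2 and compound 3 stayed within the scatter, so at this place the number can move with the group at the chain end, though only modestly in the one case shown. No measurement shown accounts for this step.

On these data alone, whether the step belongs to the fluorine atoms in particular stays open, as one trifluoromethyl example cannot show how a fluoromethyl group, a longer fluorinated chain, an amine or a carboxylic acid at this place would read in this assay. Also open, as far as these compounds go, is whether the step, seen at a single oral dose in mice, extends to other doses or routes.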